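Adding one fluoro to the benzyl of compound 1

A few compounds are considered here, and "the series" means these few. Any claim that something is new, unique, unknown or untested is made for them only; others in the source may bear on it.

Compound 1 `COc1ccc(S(=O)(=O)Oc2ccccc2/C=C(\C#N)C(=O)Nc2nnc(Cc3ccccc3)s2)cc1`: 23%
Compound 2 `N#C/C(=C\c1ccccc1OS(=O)(=O)c1ccc([N+](=O)[O-])cc1)C(=O)Nc1nnc(Cc2ccccc2)s1`: "not toxic" (no number reported)
Compound 3 `N#C/C(=C\c1ccccc1OS(=O)(=O)c1ccc(F)cc1)C(=O)Nc1nnc(Cc2ccccc2)s1`: 6%

In an ADME assay on HEK-293T cells (Homo sapiens) for inhibition, read by CCK-8 assay, with a stated time of 48 h, tested at 20 uM (on this read-out higher numbers stand for more inhibition of growth at the one concentration tested and lower numbers for less inhibition of growth), compound 1 gives 23%, the higher of the two numbers available, since compound 2 has no number. Compound 4 `COc1ccc(S(=O)(=O)Oc2ccccc2/C=C(\C#N)C(=O)Nc2nnc(Cc3cccc(F)c3)s2)cc1` differs from compound 1 in one place: fluoro in place of hydrogen on an aromatic carbon. This is fluoro in place of hydrogen on an aromatic carbon, turning benzyl into 3-fluorobenzyl. Within the data shown here, the only measured step, a number 17 percentage points lower from compound 1 to compound 3 (beyond the scatter), also brings in a fluoro, but it replaces methoxy at another place, so it is a loose guide. A small drop is expected, with a number 3 percentage points lower from compound 1 to compound 4 (within the scatter) as the estimated step. Compound 4 is estimated at 20%, with an expected range of 7% to 35%.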

Compound 4, percent growth inhibition at one concentration: 29%
Compound 4: the middle estimate sits 9 percentage points below what was measured, and the stated range covers the measured number.
By their numbers in this assay, from the lowest: compound 3; then compounds 1 and 4 (each within the scatter of the next).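

Among these compounds, the earlier compounds all carry a plain benzyl, so this is the first reading at that group. In this assay, the step is a number 6 percentage points higher from compound 1 to compound 4 (within the scatter), so on this read-out, adding fluoro to make 3-fluorobenzyl gives no distinguishable difference in growth inhibition. Nothing measured here offers an explanation for this result.

As far as these compounds go, whether a larger group on this benzyl, such as an amine, a carboxylic acid or a longer chain, would also leave the read-out unchanged remains open. So does whether 3-fluorobenzyl would behave the same way alongside the fluoro of compound 3.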